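Vinyl dihydrofuran acids and anilides: cytotoxicity notes

A few compounds are considered here, and "the series" means these few. Any claim that something is new, unique, unknown or untested is made for them only; others in the source may bear on it.

Measured compounds:
compound 1 `C=CC1=C(C(=O)O)C(c2ccc(F)cc2)OC1` gives > 100000 nM in a functional assay on SW480 cells (Homo sapiens) for cytotoxicity, read by MTT assay, with a stated time of 24 h; a higher number here means a weaker inhibitor, a lower number a stronger inhibitor; this is a limit of the assay.
compound 2 `C=CC1=C(C(=O)Nc2ccccc2)C(c2ccc(F)cc2)OC1` gives > 100000 nM in this assay; this is a limit of the assay.
compound 3 `C=CC1=C(C(=O)O)C(c2ccc(OC)c(OC)c2)OC1` gives > 100000 nM in this assay; this is a limit of the assay.

The step anilino in place of hydroxy on a carbonyl carbon from compound 1 to compound 2 is a step that the two limits leave unreadable from compound 1 to compound 2. Its size cannot be read because of the limit of > 100000 nM in this assay, at which 3 of the 3 values shown sit.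

Compound 3 shares with compound 1 the vinyl dihydrofuran carboxylic acid; the difference between the two cores is not broken down here. The value of compound 3 is only a limit.

Compound 4 `C=CC1=C(C(=O)Nc2ccccc2)C(c2ccc(OC)c(OC)c2)OC1` is not yet measured. It differs from compound 3 by anilino in place of hydroxy on a carbonyl carbon, the same change as that from compound 1 to compound 2, at the same place, a carbonyl carbon whose other neighbours are a double-bonded ring carbon.

Among the measured compounds shown here, for compound 4 the step that the limit leaves unreadable from compound 3 to compound 4 is expected to be small or unreadable, because compound 1, compound 2 and compound 3 all sit at the limit of > 100000 nM in this assay, at which 3 of the 3 values shown sit, and the one measured instance of this change left no readable step. Compound 4 is therefore estimated at 150000 nM in this assay, within 40000 nM to 600000 nM, and most likely it will again be reported only as a limit rather than a number.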

Compound 4, half-maximal inhibitory concentration: 45100 nM
Compound 4: the middle estimate sits 3.3-fold (0.52 log units) above what was measured, within the range that was stated.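

In this assay, anilino in place of hydroxy on the carbonyl carbon gives an at least 2.2-fold lower number from compound 3 to compound 4 (0.34 log units; beyond the scatter), the only readable instance of this change among the compounds shown. On the core of compound 1 the same change cannot be read, and that pair neither supports nor contradicts a transfer between cores, because both of its values sit at a limit: the limit of > 100000 nM in this assay, at which 3 of the 4 values shown sit. The printed step sets only a minimum for the size of the change on the core of compound 3, and one readable instance does not show that the change carries from core to core or that the two cores respond differently.

Open, going by these compounds, is how a methylamino or benzylamino group on the carbonyl carbon would compare with anilino on the core of compound 3, which would test whether the aromatic ring of the anilino group is needed for a readable value. Also open, on these data alone, is whether a chloroanilino group, or a methoxy group in place of hydroxy, would give a value off the limit on either core.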